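Trading 3,4-difluorophenyl for 4-chlorophenyl

The source may hold more compounds than are shown below. What is called first, only, known or untested is meant among the compounds shown, and "the series" means these compounds.

Among the measured compounds shown here, in a functional assay on HeLa cells (Homo sapiens) for inhibition, read by MTT assay, with a stated time of 72 h (on this read-out higher numbers stand for weaker inhibition and lower numbers for stronger inhibition), compound 2 (`C=C(Br)C(=O)Nc1cccc(/C=C/C(=O)Nc2ccc(F)c(F)c2)c1`) gives 1900 nM, the lower of the two numbers so far, while compound 1 (`C=C(Br)C(=O)Nc1cccc(/C=C/C(=O)Nc2ccccc2)c1`) gives 7300 nM. Compound 3 (`C=C(Br)C(=O)Nc1cccc(/C=C/C(=O)Nc2ccc(Cl)cc2)c1`) carries 4-chlorophenyl in place of 3,4-difluorophenyl on an amide-type nitrogen. For the measured compounds named here, one measured step bears on this, a 3.8-fold lower number from compound 1 to compound 2 (0.58 log units; beyond the scatter), a modest change made at the same place. Going by the values given here, no measured compound carries 4-chlorophenyl, so a small rise in this assay is expected, perhaps none beyond the scatter. The estimated step is a 1.4-fold higher number from compound 2 to compound 3 (0.14 log units; within the scatter). For compound 3 the expected value is 2600 nM, within a range of 1100 nM to 6000 nM.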

Compound 3, half-maximal inhibitory concentration: 2800 nM
For compound 3 the middle estimate is 1.1-fold (0.03 log units) below the measured one; the measured number falls inside the stated range.
By their numbers in this assay, from the lowest: compounds 2 and 3 (each within the scatter of the next); then compound 1.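

In this assay, chloro in place of hydrogen on an aromatic carbon gives a 2.6-fold lower number from compound 1 to compound 3 (0.42 log units; beyond the scatter) and so shows that a single halogen on the phenyl is enough for a step beyond the scatter. Putting 4-chlorophenyl in place of 3,4-difluorophenyl gives a 1.5-fold higher number from compound 2 to compound 3 (0.17 log units; within the scatter) and so leaves the two substituted rings unseparated at this amide-type nitrogen. Nothing measured here gives a reason for either step. From the compounds shown here alone, what a methoxy group or a carboxylic acid on this ring would do remains open, as does the effect of a lone fluoro.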